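Swapping a pentyl chain for phenyl on an alkyne

The compounds below may be only part of what the source reports. "The series", "measured", "known", "first", "only" and "open" are said of these compounds alone.

Measured so far:
compound 1 `CCCCCC#Cc1cn([C@H]2C[C@H](O)[C@@H](CO)O2)c(=O)[nH]c1=O` gives 219 ug/mL in a functional assay on L1210 cells (Mus musculus); a higher number here means a weaker inhibitor, a lower number a stronger inhibitor
compound 2 `C#Cc1cn(C2O[C@H](CO)[C@@H](O)[C@@H]2O)c(=O)[nH]c1=O` gives 45 ug/mL in this assay
compound 3 `CC(C)(C)C#Cc1cn(C2O[C@H](CO)[C@@H](O)[C@H]2O)c(=O)[nH]c1=O` gives 300 ug/mL in this assay

Among these three numbers, compound 1 stands second highest. Its nearest neighbour is compound 3, whose number lies within the scatter of repeated measurements, so no order between these two can be read. Compound 2 is the furthest away, with a number well beyond the scatter below that of compound 1, so compound 2 is the clearly stronger inhibitor of that pair.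

The unmeasured compound 4 `O=c1[nH]c(=O)n([C@H]2C[C@H](O)[C@@H](CO)O2)cc1C#Cc1ccccc1` keeps the core and sugar of compound 1 and changes only the group on the triple bond: phenyl in place of pentyl on a triple-bonded carbon. Among the compounds with values here, no measured pair shows this exact change, so the direction has to be guessed from the neighbours alone, and the available numbers give no firm lean either way. A small step is expected, from compound 1 to compound 4 of about a 1.5-fold lower number from compound 1 to compound 4 (0.16 log units; within the scatter), not clearly beyond the scatter. Compound 4 is therefore estimated at 150 ug/mL, within a range of 40 ug/mL to 500 ug/mL.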

Compound 4, concentration for 50% inhibition: 494 ug/mL
The estimate for compound 4 lay 3.3-fold (0.52 log units) below the measured number; the range from low to high includes it.
By their numbers in this assay, from the lowest: compound 2; then compounds 1, 3 and 4 (each within the scatter of the next, the first and the last beyond it).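

In this assay, within the data shown here, phenyl in place of pentyl on a triple-bonded carbon gives a 2.3-fold higher number from compound 1 to compound 4 (0.35 log units; beyond the scatter) and so a weaker inhibitor, the first comparison at this position in which only one group changes. The step is modest, but it shows that the group on the triple bond can move this read-out, even though neither group carries a hydrogen-bond donor or acceptor. Nothing at hand explains why the ring gives the higher number.

Going by these compounds, it remains open whether a shorter chain such as methyl, a longer chain such as octyl, or a phenyl ring carrying an amine would fall nearer to pentyl or to phenyl. On these data alone, whether the same swap would have a similar effect with the sugar of compound 2 also remains unknown.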